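This account rests on a few compounds, and the source may have more. Where it says the series, first, only, none or still open, it means among the compounds named here.

Three related compounds have been tested in a functional assay on MIA PaCa-2 cells (Homo sapiens) for inhibition, read by MTT assay, with a stated time of 3 days (a lower number here means a stronger inhibitor, a higher number a weaker inhibitor), and none of them gives a number. Compound 1 (`CCCN(CCC)S(=O)(=O)c1ccc(S(=O)(=O)N2CCC[C@@H](C(=O)OCC)C2)cc1`) reads > 10000 nM in this assay, which is a limit of the assay and not a measured potency. Compound 3 (`CCOC(=O)C1CCCCN1S(=O)(=O)c1ccc(S(=O)(=O)N(CC)CC)cc1`) reads > 10000 nM, again only a limit. Compound 2 (`CCOC(=O)[C@@H]1C[C@@H](O)CN(S(=O)(=O)c2ccc(S(=O)(=O)N(CC)CC)cc2)C1`) reads > 10000 nM, and this too is a limit. Compound 2 therefore stands with the other two, as the whole set shows (the limit of > 10000 nM in this assay, at which 3 of the 3 values shown sit). No step can be read between any of these compounds.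

Compound 4 (`CCOC(=O)[C@@H]1C[C@H](O)CN(S(=O)(=O)c2ccc(S(=O)(=O)N(CC)CC)cc2)C1`) has not been measured yet. It is a change of configuration alone from compound 2 (the two compounds have the same atoms and bonds and differ only in configuration as drawn: 1 of 2 stereo elements differ; a stereocentre at a saturated ring carbon is drawn R in compound 2 and S in compound 4), with the stereocentre at a saturated ring carbon drawn R in compound 2 and S in compound 4. The same atoms and bonds remain. Among the measured compounds shown here, no measured pair shows what such a change does in this assay, so no direction is favoured and no step beyond the usual scatter is expected. The expected change a step that the limit leaves unreadable from compound 2 to compound 4 is accordingly small. For compound 4 the estimated value is 15000 nM, with an expected range from 7000 nM to 40000 nM, and a report of only a limit is the likeliest outcome.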

Compound 4, half-maximal inhibitory concentration: > 10000 nM
Compound 4 ended at the assay's limit; the forecaster's own chance of this, stated with the estimate: 85%; the middle value lies beyond the limit too.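

In this assay compound 4 gives > 10000 nM, which is a limit of the assay and not a number. Compound 2 also stands at a limit, so no step can be read between compound 2 and compound 4. The compounds shown leave open whether this change of configuration affects potency at all, and whether any of them has a measurable potency here: the limit of > 10000 nM in this assay, at which 4 of the 4 values shown sit.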